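Working notes: from compound 2 to compound 3

A few compounds are considered here, and "the series" means these few. Any claim that something is new, unique, unknown or untested is made for them only; others in the source may bear on it.

Measured compounds in a functional assay on MCF7 cells (Homo sapiens) for inhibition, read by MTT assay, with a stated time of 72 h; a higher number here means a weaker inhibitor, a lower number a stronger inhibitor:
compound 1, `O=C(OC1(C(=O)Nc2ccc([N+](=O)[O-])cc2)CCCCC1)c1ccc(C(F)(F)F)cc1`, gives 27.1 nM
compound 2, `Cc1ccccc1C(=O)OC1(C(=O)Nc2ccc([N+](=O)[O-])cc2)CCCCC1`, gives 516 nM

Compound 2 stands at the highest number of the two measured in this assay; its nearest neighbour is compound 1, and the step of a 19-fold higher number from compound 1 to compound 2 (1.28 log units; beyond the scatter) is large and beyond the scatter. That single step is the only one in hand: exchanging 4-(trifluoromethyl)phenyl on the carbonyl carbon for 2-methylphenyl weakened inhibition markedly.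

Compound 3, `O=C(OC1(C(=O)Nc2ccc([N+](=O)[O-])cc2)CCCCC1)c1ccc(Br)cc1`, is not yet measured. It differs from compound 2 by 4-bromophenyl in place of 2-methylphenyl on a carbonyl carbon. Among the compounds with values here, the change is of the same kind as the one measured step, run in the opposite sense: the 2-methylphenyl of compound 2 leaves and a 4-bromophenyl enters, which resembles the 4-(trifluoromethyl)phenyl of compound 1 more than the 2-methylphenyl of compound 2 does in its pattern of substitution. Because a 19-fold higher number from compound 1 to compound 2 (1.28 log units; beyond the scatter) was large, the expected step for compound 3 is a 7.4-fold lower number from compound 2 to compound 3 (0.87 log units; beyond the scatter), a lower number, though perhaps not the full reversal. Compound 3 is estimated at 70 nM, range 20 nM to 250 nM.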

Compound 3, half-maximal inhibitory concentration: 237 nM
Compound 3: the middle estimate sits 3.4-fold (0.53 log units) below what was measured; the range from low to high includes it.
By their numbers in this assay, from the lowest: compound 1; then compound 3; then compound 2.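

In this assay, 4-bromophenyl in place of 2-methylphenyl on the carbonyl carbon gives only a 2.2-fold lower number from compound 2 to compound 3 (0.34 log units; beyond the scatter), while bromo in place of trifluoromethyl on the aromatic carbon gives an 8.7-fold higher number from compound 1 to compound 3 (0.94 log units; beyond the scatter) and leaves compound 1 as the strongest of the three. The earlier step exchanged 4-(trifluoromethyl)phenyl for 2-methylphenyl and so changed both the group and its name-position on the phenyl together; this pair holds the 4-substituted phenyl fixed and shows that the identity of the group alone separates two compounds by a step beyond the scatter. No measurement in hand accounts for this order of the three compounds.

The compounds shown leave open whether the difference between compound 2 and compound 3 follows the bromo group itself or the change from a 2-substituted to a 4-substituted phenyl, which a 4-methylphenyl or a 2-bromophenyl on the same carbonyl carbon would separate. Also open, on these data alone, is whether the same order of the three aryl groups holds when the nitro group of the shared core gives way to an amine or a carboxylic acid.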